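Topoisomerase inhibition at one concentration across chalcone amides

The source may report more compounds than this note shows. Statements on the series, on what has been measured and on what is new or still open speak of the compounds shown alone.

Measured compounds:
compound 1 `O=C(CN1CCN(c2cc3c(cc2F)c(=O)c(C(=O)O)cn3C2CC2)CC1)Nc1ccc(C(=O)/C=C/c2cccc(Cl)c2)cc1`, 3.1% in an assay on isolated protein for inhibition of DNA topoisomerase 1 (Homo sapiens), with a stated time of 30 min, tested at 20 uM; on this read-out lower numbers stand for a weaker effect and higher numbers for a stronger effect at the one concentration tested
compound 2 `O=C(CN1CCN(c2cc3c(cc2F)c(=O)c(C(=O)O)cn3C2CC2)CC1)Nc1ccc(C(=O)/C=C/c2ccc(Cl)cc2)cc1`, 0.4%

In this assay compound 1 gives 3.1% and compound 2 gives 0.4%. The step of a number 2.7 percentage points lower from compound 1 to compound 2 (within the scatter) is within the scatter, so compound 2 cannot be told apart from compound 1; both numbers sit near the bottom of the read-out.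

Compound 3 `COc1ccc(/C=C/C(=O)c2ccc(NC(=O)CN3CCN(c4cc5c(cc4F)c(=O)c(C(=O)O)cn5C4CC4)CC3)cc2)cc1OC` is not yet measured. Its difference from compound 2 is 3,4-dimethoxyphenyl in place of 4-chlorophenyl on a double-bonded chain carbon bound to a double-bonded chain carbon. Among the compounds with values here, no measured step covers this change: the one step known, from compound 1 to compound 2, only moved a chlorine on the same ring and stayed within the scatter. Nothing in the two numbers points in either direction, and both lie low, so the expected step of a number 1.6 percentage points higher from compound 2 to compound 3 (within the scatter) is none beyond the scatter. The estimate for compound 3 in this assay is 2%, with a range from -8% to 12%.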

Compound 3, a percentage reported as inhibition, at one concentration (the size of the read-out at that concentration, not a potency): 2.5%
Estimate against measurement, compound 3: 0.5 percentage points below, within the range that was stated.
By their numbers in this assay, from the lowest: compounds 2, 3 and 1 (each within the scatter of the next).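

In this assay, replacing the chlorinated ring with 3,4-dimethoxyphenyl on a double-bonded chain carbon bound to a double-bonded chain carbon gives a number 2.1 percentage points higher from compound 2 to compound 3 (within the scatter) and a number 0.6 percentage points lower from compound 1 to compound 3 (within the scatter). The earlier pair only moved a chlorine on the same ring; here the chlorine is gone, and the entering group brings more heavy atoms and hydrogen-bond acceptors, yet neither step leaves the scatter. No available evidence bears on why this exchange leaves the read-out unresolved.

Still open, on these data alone, is whether any group at this place can move the read-out beyond the scatter, for example a hydroxyl or an amine on this ring, or a pyridine ring in place of the phenyl. The three compounds also say nothing about changes elsewhere on the shared core.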